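Adding trifluoromethyl to a benzyl-bearing compound

The source may report more compounds than this note shows. Statements on the series, on what has been measured and on what is new or still open speak of the compounds shown alone.

Values in a functional assay on THP-1 cells (Homo sapiens) for inhibition, read by ELISA, with stated times of 2 h and 48 h; on this read-out higher numbers stand for weaker inhibition and lower numbers for stronger inhibition:
Compound 1 `[O-]/[N+](=C\c1cn(-c2ccccc2)nn1)c1ccccc1`: 8800 nM
Compound 2 `[O-]/[N+](=C\c1cn(CCC(F)(F)C(F)(F)C(F)(F)C(F)(F)C(F)(F)C(F)(F)C(F)(F)C(F)(F)F)nn1)c1ccccc1`: 11700 nM
Compound 3 `[O-]/[N+](=C\c1cn(-c2ccccc2)nn1)Cc1ccccc1`: 8000 nM

Compound 3 stands within the usual scatter of both other compounds, so the three values give no order among them. Compound 4 `[O-]/[N+](=C\c1cn(-c2ccc(C(F)(F)F)cc2)nn1)Cc1ccccc1` differs from compound 3 by one change: trifluoromethyl in place of hydrogen on an aromatic carbon. Among the compounds with values here, no measured step tests this change. Within the data shown here, the only step available, a 1.1-fold lower number from compound 1 to compound 3 (0.04 log units; within the scatter), concerns another place in the structure, so it bears only indirectly. With all three values this close, no shift beyond the scatter is expected in this assay. The expected change is a 1.1-fold lower number from compound 3 to compound 4 (0.06 log units; within the scatter). For compound 4 the estimated value is 7000 nM, with an expected range from 3000 nM to 16000 nM.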

Compound 4, half-maximal inhibitory concentration: 15400 nM
Compound 4: middle estimate off by 2.2-fold (0.34 log units), on the low side; the range from low to high includes it.
By their numbers in this assay, from the lowest: compounds 3, 1, 2 and 4 (each within the scatter of the next).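

In this assay, within the data shown here, trifluoromethyl in place of hydrogen on an aromatic carbon, para to a large group, gives a 1.9-fold higher number from compound 3 to compound 4 (0.28 log units; within the scatter) and so supplies the first direct reading of this change. The step lies within the scatter, so at this position the values of the trifluoromethyl and hydrogen compounds cannot be told apart. Nothing at hand offers an explanation for this result. On these data alone, whether an amine, a carboxylic acid or a methoxy group at this position would move the value beyond the scatter remains open.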